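Solubility of a Quinolone Ester Across Aryl Substitution Patterns

A few compounds are considered here, and "the series" means these few. Any claim that something is new, unique, unknown or untested is made for them only; others in the source may bear on it.

Compound 1 `CCOC(=O)c1c(-c2cccc(C(F)(F)F)c2)[nH]c2cc(OC)ccc2c1=O` — 19000 nM
Compound 2 `CCOC(=O)c1c(-c2ccccc2C)[nH]c2cc(OC)ccc2c1=O` — > 100000 nM
Compound 3 `CCOC(=O)c1c(-c2ccc(OC)cc2)[nH]c2cc(OC)ccc2c1=O` — 8000 nM

Three compounds sharing one core have been examined in a physicochemical assay for solubility, in phosphate buffer, at pH 7.4; on this read-out higher numbers stand for higher solubility and lower numbers for lower solubility. For compound 2 the reading is a limit of the assay, > 100000 nM, so only a floor is known there (the limit of > 100000 nM in this assay, at which 1 of the 3 values shown sits). Compound 1 gives 19000 nM, while compound 3 gives 8000 nM. On the numbers shown, compound 3 stands lowest of the two measured values, with compound 1 as its nearest neighbour at a higher figure, and one further reading being a limit. Going by the values given here, the single counted step, an at least 12-fold lower number from compound 2 to compound 3 (1.09 log units; beyond the scatter), shows that moving the substituent and changing its identity on the pendant aryl ring can shift solubility strongly.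

Compound 4 `CCOC(=O)c1c(-c2cccc(OC)c2)[nH]c2cc(OC)ccc2c1=O` has not yet been measured. It differs from compound 3 by 3-methoxyphenyl in place of 4-methoxyphenyl on an aromatic carbon. Among the compounds with values here, no measured step matches this exact change; the only comparison available is that compound 1, which also carries a group on the ring in the same relative sense as the entering 3-methoxyphenyl, sits higher than compound 3. On that slender basis, compound 4 is expected to give a modestly higher solubility, a step of a 1.9-fold higher number from compound 3 to compound 4 (0.27 log units; within the scatter), with an estimate of 15000 nM and a range from 5000 nM to 45000 nM.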

Compound 4, solubility: > 100000 nM
Compound 4: only a limit was reported (the forecaster's own chance of this, stated with the estimate: 5%); middle value at least 6.6-fold (0.82 log units) away from the limit.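

The earlier step from compound 2 to compound 3 changed both the group and its place on the pendant ring, whereas here the methoxy group stays and only its place changes, with the same atoms joined differently: the change to 3-methoxyphenyl from 4-methoxyphenyl gives an at least 12-fold higher number from compound 3 to compound 4 (1.09 log units; beyond the scatter). Placing alone is therefore enough to move the reading in this assay well beyond the scatter in this pair. The choice of group also counts among the compounds shown, since methoxy in place of trifluoromethyl gives an at least 5.2-fold higher number from compound 1 to compound 4 (0.72 log units; beyond the scatter), while the step between compound 2 and compound 4 cannot be read, as both readings are limits: the limit of > 100000 nM in this assay, at which 2 of the 4 values shown sit.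

As far as these compounds go, how far compound 4 actually lies past its limit stays unknown, so both of its readable steps give only a minimum size and the true gaps may be much wider. Also open, from the compounds shown here alone, is whether the same place would give a similar reading with a different group there, such as an amine or a longer alkoxy chain in place of methoxy, or with a carboxylic acid in place of the ethoxycarbonyl group.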